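The source may report more compounds than this note shows. Statements on the series, on what has been measured and on what is new or still open speak of the compounds shown alone.

In a functional assay on K562 cells (Homo sapiens) for cytotoxicity, read by MTT assay, with a stated time of 48 h (a higher number here means a weaker inhibitor, a lower number a stronger inhibitor), compound 1 `COc1ccc(-c2c(-c3cc(OC)c(OC)c(OC)c3)noc2NC(C)=O)cc1` gives 380 nM and compound 2 `COc1cc(-c2noc(NC(C)=O)c2-c2ccc(Cl)cc2)cc(OC)c1OC` gives 3620 nM, while compound 3 `COc1ccc(-c2c(-c3cc(OC)c(OC)c(OC)c3)noc2N(C(C)=O)C(C)=O)cc1` gives 68 nM as the lowest of the three numbers. Compound 3 therefore stands as the strongest inhibitor measured so far in this small set. Compound 4 `COc1cc(-c2noc(N(C(C)=O)C(C)=O)c2-c2ccc(Cl)cc2)cc(OC)c1OC` has not yet been measured. It differs from compound 3 by chloro in place of methoxy on an aromatic carbon, para to a large group, which reads as 4-methoxyphenyl to 4-chlorophenyl (chloro in place of methoxy on an aromatic carbon).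

Among the measured compounds shown here, two measured steps bear on this change. The same exchange appears in a 9.5-fold higher number from compound 1 to compound 2 (0.98 log units; beyond the scatter) as a modest weakening beyond the scatter. The other step, a 5.6-fold lower number from compound 1 to compound 3 (0.75 log units; beyond the scatter) for acetyl in place of hydrogen on an amide-type nitrogen, is a modest strengthening beyond the scatter, and both compound 3 and compound 4 carry that extra acetyl. For the measured compounds named here, whether the exchange keeps its size in the presence of that acetyl is untested, and only one precedent exists. A modest step of similar size toward a higher number is therefore expected in this assay, with a wide margin. The expected change is an 8.8-fold higher number from compound 3 to compound 4 (0.95 log units; beyond the scatter) on this reasoning. For compound 4 the estimate is 600 nM with an expected range of 170 nM to 2200 nM in this read-out.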

Compound 4, half-maximal inhibitory concentration: 3960 nM
Estimate against measurement, compound 4: 6.6-fold (0.82 log units) below; measured number above the stated range.
By their numbers in this assay, from the lowest: compound 3; then compound 1; then compounds 2 and 4 (each within the scatter of the next).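

In this assay, with the extra acetyl on the amide-type nitrogen, chloro in place of methoxy becomes a large step, a 58-fold higher number from compound 3 to compound 4 (1.77 log units; beyond the scatter), so the size of this exchange at the aromatic carbon depends on what the nitrogen carries: the same change on two cores in this assay, a 9.5-fold higher number (0.98 log units; beyond the scatter) from compound 1 to compound 2 and a 58-fold higher number (1.77 log units; beyond the scatter) from compound 3 to compound 4, 6.1-fold (0.79 log units) apart, beyond the scatter of two such steps Read the other way, the extra acetyl counts only with the 4-methoxyphenyl group in place, since with 4-chlorophenyl it gives a 1.1-fold higher number from compound 2 to compound 4 (0.04 log units; within the scatter): the same change on two cores in this assay, a 5.6-fold lower number (0.75 log units; beyond the scatter) from compound 1 to compound 3 and a 1.1-fold higher number (0.04 log units; within the scatter) from compound 2 to compound 4, 6.1-fold (0.79 log units) apart, beyond the scatter of two such steps The two changes therefore do not add across these four compounds, and the gain from the extra acetyl appears only in compound 3, while compound 2 and compound 4 sit within the scatter of each other.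

The compounds shown leave open whether this dependence belongs to methoxy itself or would also hold with a methyl, a hydroxy or a dimethylamino group on that aromatic carbon. They also leave open whether a propionyl group, with its longer chain, would behave as the extra acetyl does on the nitrogen, with either 4-methoxyphenyl or 4-chlorophenyl in place.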